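The source may report more compounds than this note shows. Statements on the series, on what has been measured and on what is new or still open speak of the compounds shown alone.

Series notes, compound 1 to compound 3.

Compound 1 `COc1ccccc1N1CCN(CCCNc2ncccc2C(=O)N(C)C)CC1` gives 1.59 nM in a functional assay for antagonist activity at Alpha-1A adrenergic receptor (Oryctolagus cuniculus) (a lower number here means tighter binding, a higher number weaker binding), and stands highest of the two numbers in hand. Its nearest neighbour is compound 2 `COc1ccccc1N1CCN(CCCNc2ncc(C#N)cc2C(=O)N(C)C)CC1`, which in this assay gives 0.794 nM; the step of a 2.0-fold lower number from compound 1 to compound 2 (0.30 log units; within the scatter), cyano in place of hydrogen on an aromatic carbon, stays within the scatter.

Compound 3 `CCCc1ccccc1N1CCN(CCCNc2ncccc2C(=O)N(C)C)CC1` differs from compound 1 by propyl in place of methoxy on an aromatic carbon. Going by the values given here, no measured step bears on this change: the only step recorded, from compound 1 to compound 2, alters a different part of the shared core and is itself within the scatter, so it gives no guide to the size or direction of the present change.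

The expectation is therefore a step of a 1.9-fold higher number from compound 1 to compound 3 (0.28 log units; within the scatter), with no confident direction beyond the scatter. Compound 3 is estimated at 3 nM in this assay, in the range 0.8 nM to 12 nM.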

Compound 3, dissociation constant: 0.2 nM
For compound 3 the middle estimate is 15-fold (1.18 log units) above the measured one, and the stated range ends above it.
By their numbers in this assay, from the lowest: compound 3; then compounds 2 and 1 (each within the scatter of the next).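

In this assay, going by these compounds alone, the step of an 8.0-fold lower number from compound 1 to compound 3 (0.90 log units; beyond the scatter) is the only recorded step that lies beyond the scatter, so this position on the aromatic ring, ortho to a large group, is the one place so far where a change clearly moves the number. It also shows that the methoxy, with its hydrogen-bond acceptor, is not required for a low number on this core: propyl, with no hydrogen-bond acceptor, gives a lower one. Nothing at hand accounts for the size of this step.

Compound 3 changes both the chain length and the oxygen at once, so ethyl, butyl and ethoxy at this position would be needed to separate the two. On these data alone, whether the nitrile of compound 2 combines with propyl, and how an amine or a carboxylic acid would fare here, stays open.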